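The compounds below may be only part of what the source reports. "The series", "measured", "known", "first", "only" and "open" are said of these compounds alone.

Compound 2 `Nc1ccccc1NC(=O)c1ccc(CSC(=S)N2CCCc3ccccc32)cc1` stands second highest of the three numbers in a functional assay on MGC-803 cells (Homo sapiens) for antiproliferative activity, read by CCK-8 assay, with a stated time of 72 h, tested at 2 uM (on this read-out higher numbers stand for a stronger effect at the one concentration tested and lower numbers for a weaker effect), where compound 2 gives 38.5%. Its nearest neighbour is compound 1 `Nc1ccccc1NC(=O)c1ccc(CSC(=S)N2CCN(Cc3ccccn3)CC2)cc1`, which in this assay gives 23.4%, and the furthest is compound 3 `Nc1ccccc1NC(=O)c1ccc(CSC(=S)N2CCN(c3ccncc3)CC2)cc1`, which in this assay gives 64.8%. For the measured compounds named here, the single measured step, a number 41.4 percentage points higher from compound 1 to compound 3 (beyond the scatter), concerns a different part of the shared core and does not bear on the change now considered. Compound 4 `Nc1ccccc1NC(=O)c1ccc(CSC(=S)N2CCCC2)cc1` differs from compound 2 by pyrrolidin-1-yl in place of 1,2,3,4-tetrahydroquinolin-1-yl on a thiocarbonyl carbon. Going by the values given here, with no measured step touching this position, neither direction nor size can be anchored, so the expected step of a number 3.5 percentage points lower from compound 2 to compound 4 (within the scatter) is held within the scatter and carries a wide range. Compound 4 is therefore estimated to give 35%, between 10% and 60%.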

Compound 4, a percentage reported as inhibition, at one concentration (the size of the read-out at that concentration, not a potency): 27%
The estimate for compound 4 lay 8 percentage points above the measured number, and the stated range covers the measured number.
By their numbers in this assay, from the lowest: compounds 1 and 4 (each within the scatter of the next); then compound 2; then compound 3.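

In this assay the thiocarbonyl carbon gets its first measured step, and the change is beyond the scatter: a number 11.5 percentage points lower from compound 2 to compound 4 (beyond the scatter). The group on this carbon therefore affects the read-out, and here pyrrolidin-1-yl, which lacks the six-membered aromatic ring of 1,2,3,4-tetrahydroquinolin-1-yl, goes with the lower number. Nothing available explains this difference. On these data alone, it remains open whether the aromatic ring or the ring size matters more, and how a piperidin-1-yl, a morpholin-4-yl or an open-chain diethylamino group on this carbon would compare.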